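Cyanoguanidines: swapping cyclopentyl for propyl

A few compounds are considered here, and "the series" means these few. Any claim that something is new, unique, unknown or untested is made for them only; others in the source may bear on it.

Of the compounds shown here, two have numbers so far. In a functional assay on Beta-TC3 cells (Rattus norvegicus) with Beta-TC3 (Mus musculus) as the target, using a membrane potential dye (on this read-out lower numbers stand for stronger inhibition and higher numbers for weaker inhibition), compound 1, with structure `C[C@H](/N=C(\NC#N)Nc1cc(Cl)cc(Cl)c1)c1ccccc1`, gives 25000 nM. Compound 2, with structure `N#CN/C(=N\C1CCCC1)Nc1cc(C(F)(F)F)cc(C(F)(F)F)c1`, gives 4700 nM in this assay, the lowest of the two numbers; compound 1 stands a good way higher, beyond the usual scatter. Compound 3, with structure `CCC/N=C(\NC#N)Nc1cc(C(F)(F)F)cc(C(F)(F)F)c1`, has not yet been measured. It differs from compound 2 in one place: propyl in place of cyclopentyl on a double-bonded nitrogen. The cyclopentyl that leaves is a five-membered non-aromatic ring of carbon only, and the propyl that enters is a shorter open chain. Among the compounds with values here, no measured pair shows what such a swap does here, so any expectation rests on compound 2 alone. A modest move toward weaker inhibition, near the edge of the scatter, is expected as the step of a 1.7-fold higher number from compound 2 to compound 3 (0.23 log units; within the scatter). Compound 3 is therefore estimated at 8000 nM, in the range 3000 nM to 25000 nM.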

Compound 3, half-maximal inhibitory concentration: 19000 nM
For compound 3 the middle estimate is 2.4-fold (0.38 log units) below the measured one; the range from low to high includes it.
By their numbers in this assay, from the lowest: compound 2; then compounds 3 and 1 (each within the scatter of the next).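

Within the data shown here, this pair differs in one place only, so it gives the first direct reading of this position: in this assay, the change from cyclopentyl to propyl on the double-bonded nitrogen is a 4.0-fold higher number from compound 2 to compound 3 (0.61 log units; beyond the scatter). The group at this position therefore affects the read-out, and here the five-membered ring of carbon only, with 5 heavy atoms, goes with stronger inhibition than the open propyl chain, with 3 heavy atoms. No measurement at hand explains this difference.

This one step cannot show whether the ring itself or the number of carbons matters more, a question that pentyl, an open chain of five carbons, or cyclobutyl, a smaller carbon ring, could help settle. It also leaves open how this position would respond to a group carrying an amine or a carboxylic acid.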